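The source may hold more compounds than are shown below. What is called first, only, known or untested is meant among the compounds shown, and "the series" means these compounds.

Compound 1 `CCN(CC)CCC1=C(C(C)c2ccccn2)c2ccccc2C1` and compound 2 `CC(C1=C(CCN(C)C(C)C)Cc2ccccc21)c1ccccn1` share a core and differ only at the amine: the change from compound 1 to compound 2 exchanges diethylamino for isopropyl(methyl)amino on a saturated chain carbon, two bonds along the chain from a double-bonded ring carbon. In an assay on CHO-K1 cells for binding affinity to muscarinic acetylcholine receptor M5 (Homo sapiens) (on this read-out lower numbers stand for stronger inhibition and higher numbers for weaker inhibition), compound 1 gives 2090 nM, and compound 2 gives 2190 nM, so a 1.0-fold higher number from compound 1 to compound 2 (0.02 log units; within the scatter) and the two compounds cannot be separated on this assay. Going by the values given here, compound 2 thus stands with the one other number within the scatter.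

Compound 3 `CC(C1=C(CN(C)C(C)C)Cc2ccccc21)c1ccccn1` keeps the isopropyl(methyl)amino group but is one chain carbon shorter: isopropyl(methyl)amino in place of (isopropyl(methyl)amino)methyl on a saturated chain carbon bound to a double-bonded ring carbon. Among the compounds with values here, no measured step touches the chain length, so the only step in hand, which left the number unchanged, gives no guidance on direction. A modest shift in either direction is expected, a 1.2-fold higher number from compound 2 to compound 3 (0.07 log units; within the scatter), with compound 3 estimated at 2600 nM, between 800 nM and 8500 nM.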

Compound 3, inhibition constant: 1120 nM
For compound 3 the middle estimate is 2.3-fold (0.37 log units) above the measured one; the measured number falls inside the stated range.
By their numbers in this assay, from the lowest: compounds 3, 1 and 2 (each within the scatter of the next).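

In this assay the shorter chain gives a 2.0-fold lower number from compound 2 to compound 3 (0.29 log units; within the scatter) and, with the amine exchanged as well, a 1.9-fold lower number from compound 1 to compound 3 (0.27 log units; within the scatter) as the second reading. Going by these compounds alone, this is the first test of chain length at this position, since the earlier step changed only the amine: going from 2-(isopropyl(methyl)amino)ethyl to (isopropyl(methyl)amino)methyl does not separate compound 3 from compound 2, and all three compounds remain within the scatter of one another. Nothing available explains this result.

The compounds shown leave open whether a longer chain, or a primary amine in place of isopropyl(methyl)amino, would move the number beyond the scatter. They also leave open whether any change at this position can separate compounds on this read-out.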